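Compound 4 adds an ethoxy group to compound 3

The source may report more compounds than this note shows. Statements on the series, on what has been measured and on what is new or still open speak of the compounds shown alone.

Compound 1 `Cc1ccc(NC2=CC(=O)c3nc4n(c3C2=O)[C@H]2OC[C@@H](O)[C@H]2OC4)cc1C`: 2820 nM
Compound 2 `CCc1ccc(NC2=CC(=O)c3nc4n(c3C2=O)[C@H]2OC[C@@H](O)[C@H]2OC4)cc1`: 3080 nM
Compound 3 `O=C1C=C(Nc2ccccc2)C(=O)c2c1nc1n2[C@H]2OC[C@@H](O)[C@H]2OC1`: 4970 nM

In a functional assay on ECa-109 cells for inhibition, with ECa-109 cell line (Homo sapiens) as the target, read by sulforhodamine B assay (on this read-out lower numbers stand for stronger inhibition and higher numbers for weaker inhibition), compound 3 gives 4970 nM, the highest of the three numbers, yet both a 1.6-fold higher number from compound 2 to compound 3 (0.21 log units; within the scatter) and a 1.8-fold higher number from compound 1 to compound 3 (0.25 log units; within the scatter) stay within the scatter, as does a 1.1-fold higher number from compound 1 to compound 2 (0.04 log units; within the scatter). Compound 4 `CCOc1ccccc1NC1=CC(=O)c2nc3n(c2C1=O)[C@H]1OC[C@@H](O)[C@H]1OC3` differs from compound 3 by ethoxy in place of hydrogen on an aromatic carbon. Going by the values given here, every measured step alters the same six-membered ring, and none of them moved this assay beyond the scatter; no measured step brings in an ethoxy group at this place, so no direct precedent exists. The step is therefore expected to be small, a 1.3-fold lower number from compound 3 to compound 4 (0.12 log units; within the scatter). Compound 4 is estimated at 3800 nM, with a range from 1600 nM to 9500 nM.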

Compound 4, half-maximal inhibitory concentration: 4630 nM
Beside the measured number, compound 4's estimate is 1.2-fold (0.09 log units) below it, within the range that was stated.
By their numbers in this assay, from the lowest: compounds 1, 2, 4 and 3 (each within the scatter of the next).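

Going by these compounds alone, on the phenyl ring, ethoxy ortho to a large group adds a kind of substituent and a place that the earlier compounds did not cover, yet in this assay a 1.1-fold lower number from compound 3 to compound 4 (0.03 log units; within the scatter) still lies within the scatter. The 2-ethoxyphenyl group also stays within the scatter of the other two rings, with a 1.5-fold higher number from compound 2 to compound 4 (0.18 log units; within the scatter) and a 1.6-fold higher number from compound 1 to compound 4 (0.22 log units; within the scatter) as the printed steps. Nothing available explains why this step is small. Going by these compounds, whether an amine, a carboxylic acid or a longer chain at this place would move the number beyond the scatter remains open. So does whether ethoxy on another carbon of this ring would do so.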